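Moving the chlorine around the ring: compound 1 to compound 4

The source may hold more compounds than are shown below. What is called first, only, known or untested is meant among the compounds shown, and "the series" means these compounds.

Among the measured compounds shown here, the three compounds measured so far share a core carrying a methylamide and a second amide. Compound 1 `CNC(=O)c1cc(C(=O)N[C@H]2CC[C@H](O)CC2)c([C@@H](C)c2ccc(Cl)cc2)o1` gives 3.5 in a physicochemical assay for lipophilicity (on this read-out lower numbers stand for lower lipophilicity and higher numbers for higher lipophilicity), the largest number among the three. Compound 2 `CNC(=O)c1cc(C(=O)N[C@H]2[C@@H]3C[C@@H](O)C[C@@H]32)n([C@@H](C)c2ccccc2)n1` gives 3.2, which sits within the usual scatter of compound 1, so no order between them can be claimed. Compound 3 `CNC(=O)c1cc(C(=O)NC2CC2)n(Cc2ccccc2)n1` gives 3.1, a gap from compound 1 that lies beyond the scatter.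

Compound 4 `CNC(=O)c1cc(C(=O)N[C@H]2CC[C@H](O)CC2)c([C@@H](C)c2cccc(Cl)c2)o1` has not yet been measured. It differs from compound 1 by one counted change: 3-chlorophenyl in place of 4-chlorophenyl on a saturated chain carbon bound to an aromatic carbon and a saturated chain carbon. The same atoms are present, only joined differently, and neither donors nor acceptors change. For the measured compounds named here, with no measured step of this kind available, the expected step from compound 1 to compound 4 is a number 0.10 log units lower from compound 1 to compound 4 (within the scatter), that is, none beyond the scatter. Compound 4 is therefore estimated at 3.4, with a range from 3.1 to 3.7.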

Compound 4, distribution coefficient: 3.5
Compound 4: middle estimate off by 0.10 log units, on the low side, and the stated range covers the measured number.
By their numbers in this assay, from the lowest: compounds 3, 2, 1 and 4 (each within the scatter of the next, the first and the last beyond it).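

In this assay the change to 3-chlorophenyl on this saturated chain carbon gives no change at the digits printed from compound 1 to compound 4 (within the scatter) and so does not separate the two chlorine placements on the core of compound 1. Among the compounds shown here, this is the first direct one-place comparison, since the earlier compounds differ in several places at once. No measurement here bears on why the two placements read alike.

As far as these compounds go, whether an amine or a carboxylic acid in place of the chlorine would shift the number remains open. So does whether the same chlorine move reads alike on a different core.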